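The compounds below may be only part of what the source reports. "The series", "measured", "known", "first", "only" and "open" are said of these compounds alone.

In a functional assay on MKN-45 cells (Homo sapiens) for cytotoxicity, read by MTT assay, with a stated time of 72 h (a higher number here means a weaker inhibitor, a lower number a stronger inhibitor), compound 3 `COc1cc2c(Oc3ccc(NC(=O)c4cc(-c5cccc(Cl)c5)nc5ccc(F)cc45)cc3F)ccnc2cc1OCCCN1CCC(C)CC1` gives 10 nM, the lowest of the three numbers. Among the compounds with values here, compound 1 `COc1cc2c(Oc3ccc(NC(=O)c4cc(-c5cccc(Cl)c5)nc5ccccc45)cc3F)ccnc2cc1OCCCN1CCC(C)CC1` gives 30 nM, and the single change a 3.0-fold lower number from compound 1 to compound 3 (0.48 log units; beyond the scatter) separates the two. Within the data shown here, compound 2 `COc1cccc(-c2cc(C(=O)Nc3ccc(Oc4ccnc5cc(OCCCN6CCCCC6)c(OC)cc45)c(F)c3)c3cc(F)ccc3n2)c1` gives 690 nM; it differs from compound 3 in two places, so no single step links them. Compound 4 `COc1cccc(-c2cc(C(=O)Nc3ccc(Oc4ccnc5cc(OCCCN6CCC(C)CC6)c(OC)cc45)c(F)c3)c3cc(F)ccc3n2)c1` carries just one of those two differences: methoxy in place of chloro on an aromatic carbon. Among the measured compounds shown here, no measured step isolates this exchange. Compound 2 and compound 4 share the methoxy group and differ in only one other place, and the wide gap between compound 2 and compound 3 suggests that much of it may follow the methoxy. Compound 4 is therefore expected at 300 nM, between 60 nM and 1500 nM, the step of a 30-fold higher number from compound 3 to compound 4 (1.48 log units; beyond the scatter) expected to be large and upward.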

Compound 4, half-maximal inhibitory concentration: 730 nM
Compound 4: the middle estimate sits 2.4-fold (0.39 log units) below what was measured, and the stated range covers the measured number.
By their numbers in this assay, from the lowest: compound 3; then compound 1; then compounds 2 and 4 (each within the scatter of the next).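

In this assay, the change from 3-chlorophenyl to 3-methoxyphenyl now has a step of its own, a 73-fold higher number from compound 3 to compound 4 (1.86 log units; beyond the scatter), so this one place on the aromatic ring can move the number by a large amount. The methyl on the saturated ring carbon, with methoxy present, gives a 1.1-fold higher number from compound 2 to compound 4 (0.02 log units; within the scatter), so those two compounds cannot be told apart. Nothing measured here explains the size of the chloro-to-methoxy step. Going by these compounds, how a hydroxyl, an amine or a longer alkoxy chain would read at this place remains open. So does whether the methyl step would stay as small with chloro present.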